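The source may report more compounds than this note shows. Statements on the series, on what has been measured and on what is new or still open speak of the compounds shown alone.

Compound 1 `CC(C)OCC1=CS(=O)(=O)c2ccccc2C1=O` gives 99.2% in a functional assay on the whole organism for inhibition, with Mus musculus as the target, at a dose of 10 mg/kg; on this read-out higher numbers stand for more inhibition at the one dose given (going by the name of the read-out) and lower numbers for less inhibition.
Compound 2 `CC(=O)OCC1=CS(=O)(=O)c2ccccc2C1=O` gives 99.5% in this assay.

Compound 2 stands at the top of the two numbers shown, with compound 1 nearest, but the step of a number 0.3 percentage points higher from compound 1 to compound 2 (within the scatter) is within the scatter, so the two compounds cannot be told apart on these readings; the two numbers are level with each other at the single dose used.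

Compound 3 `CCC(=O)OCC1=CS(=O)(=O)c2ccccc2C1=O` is the next compound. Its change from compound 2 is methyl in place of hydrogen on a saturated chain carbon bound to a carbonyl carbon. For the measured compounds named here, the one measured step, a number 0.3 percentage points higher from compound 1 to compound 2 (within the scatter), concerns the same oxygen-bound group and exchanged a whole isopropyl for an acetyl without moving the read-out beyond the scatter. The change to compound 3 is smaller still, adding one carbon to that acetyl. With both measured compounds already near the ceiling of the read-out, a step beyond the scatter in either direction is not expected; the expected step is a number 0.5 percentage points lower from compound 2 to compound 3 (within the scatter).

Compound 3 is therefore estimated at 99%, with a range from 94% to 100%.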

Compound 3, a percentage reported as inhibition, in the whole organism at one dose (the size of the read-out at that dose, not a potency): 99.5%
The estimate for compound 3 lay 0.5 percentage points below the measured number, within the range that was stated.
By their numbers in this assay, from the lowest: compounds 1, 2 and 3 (each within the scatter of the next).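

In this assay, lengthening the acetyl of compound 2 to the propanoyl of compound 3 gives no change at the digits printed from compound 2 to compound 3 (within the scatter), so adding a methyl on the saturated chain carbon bound to a carbonyl carbon leaves the read-out level. This is the first change shown within the acyl group itself, whereas the earlier step exchanged one whole group on the oxygen for another. The exchange of isopropyl for propanoyl on an oxygen on a saturated carbon gives a number 0.3 percentage points higher from compound 1 to compound 3 (within the scatter), so acetyl, propanoyl and isopropyl all stand level here, and no data shown offer an explanation for this.

As far as these compounds go, it remains open whether the read-out would stay level with a much longer acyl chain such as hexanoyl, with a benzoyl, or with an amine carried on the chain. All three compounds sit close together near the top of the scale at the one dose given, so any difference in strength between them could only be sought at other doses, and these numbers say nothing about that.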